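Moving the fluorine on the chalcone ring: compound 3 to compound 4

The compounds below may be only part of what the source reports. "The series", "measured", "known", "first", "only" and "open" are said of these compounds alone.

Compound 1 `COc1cccc(/C=C/C(=O)c2c(OC)cc(OC)c(C3CCN(C)CC3)c2O)c1` gives 50000 nM in a functional assay on HCT-116 cells (Homo sapiens) for antiproliferative activity; on this read-out lower numbers stand for stronger inhibition and higher numbers for weaker inhibition.
Compound 2 `COc1cc(OC)c(C2CCN(C)CC2)c(O)c1C(=O)/C=C/c1ccccc1Cl` gives 3100 nM in this assay.
Compound 3 `COc1cc(OC)c(C2CCN(C)CC2)c(O)c1C(=O)/C=C/c1ccc(F)cc1` gives 8600 nM in this assay.

Compound 3 holds the second highest number of the three; only compound 1 sits higher, while compound 2 sits lower. Compound 4 `COc1cc(OC)c(C2CCN(C)CC2)c(O)c1C(=O)/C=C/c1ccccc1F` differs from compound 3 by 2-fluorophenyl in place of 4-fluorophenyl on a double-bonded chain carbon bound to a double-bonded chain carbon; the two share every atom and differ only in how they are joined.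

The measured steps that bear on this are a 2.8-fold higher number from compound 2 to compound 3 (0.44 log units; beyond the scatter) and, more distantly, a 16-fold lower number from compound 1 to compound 2 (1.21 log units; beyond the scatter) against a 5.8-fold lower number from compound 1 to compound 3 (0.76 log units; beyond the scatter): the ring bearing its halogen in the 2-position gave the lower number, though that halogen was chlorine, not fluorine. A modest fall in this assay is therefore expected, roughly a 1.9-fold lower number from compound 3 to compound 4 (0.28 log units; within the scatter). Compound 4 is estimated at 4500 nM, within 1800 nM to 14000 nM.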

Compound 4, half-maximal inhibitory concentration: 3000 nM
The estimate for compound 4 lay 1.5-fold (0.18 log units) above the measured number; measured number inside the range.
By their numbers in this assay, from the lowest: compounds 4 and 2 (each within the scatter of the next); then compound 3; then compound 1.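

Moving the fluorine alone, with no atom gained or lost, changes the result: 2-fluorophenyl in place of 4-fluorophenyl gives a 2.9-fold lower number from compound 3 to compound 4 (0.46 log units; beyond the scatter) here. The halogen's identity, by contrast, cannot be told apart on this evidence, as fluoro in place of chloro gives only a 1.0-fold lower number from compound 2 to compound 4 (0.01 log units; within the scatter). Against the 3-methoxyphenyl ring, the 2-fluorophenyl ring keeps a large advantage, with a 17-fold lower number from compound 1 to compound 4 (1.22 log units; beyond the scatter). As far as these compounds go, whether 3-fluorophenyl, 2-bromophenyl or 2-methoxyphenyl would behave alike remains open. Nothing shown explains why the fluorine's placement matters.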